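A few compounds are considered here, and "the series" means these few. Any claim that something is new, unique, unknown or untested is made for them only; others in the source may bear on it.

Values in a physicochemical assay for solubility (a higher number here means a more soluble compound, a lower number a less soluble compound), so far:
- compound 1 (`COc1ccc2c(c1)CN(C(=O)c1cc(S(C)(=O)=O)ccc1O[C@@H](C)C(F)(F)F)C2`) gives 46 ug/mL on the shared core
- compound 2 (`C[C@H](Oc1ccc(S(C)(=O)=O)cc1C(=O)N1Cc2ccc(-c3ccncc3)cc2C1)C(F)(F)F`) gives 25 ug/mL on the same core

Among the compounds with values here, compound 2 stands within the scatter of compound 1, the only other measured compound, so it holds no distinct rank yet.

Next is compound 3 (`C[C@H](Oc1ccc(S(C)(=O)=O)cc1C(=O)N1Cc2ccc(C3CCOCC3)cc2C1)C(F)(F)F`), with oxan-4-yl in place of pyridin-4-yl on an aromatic carbon. The six-membered ring stays, but it is no longer aromatic, and its hetero atom is oxygen instead of nitrogen.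

Within the data shown here, no measured step involves oxan-4-yl, so the evidence is indirect. Among the measured compounds shown here, the one relevant step is a 1.8-fold lower number from compound 1 to compound 2 (0.26 log units; within the scatter) for pyridin-4-yl in place of methoxy, and this stayed within the scatter. A single step sets no pattern, but it gives no reason to expect a large move. In this assay no step beyond the scatter is expected, and no firm direction can be given. The expected step is a 1.2-fold higher number from compound 2 to compound 3 (0.08 log units; within the scatter) on this reading. For compound 3 the estimated value is 30 ug/mL with an expected range from 12 ug/mL to 75 ug/mL until the measurement is available.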

Compound 3, solubility: 76 ug/mL
Compound 3: middle estimate off by 2.5-fold (0.40 log units), on the low side, and the stated range ends below it.
By their numbers in this assay, from the lowest: compounds 2, 1 and 3 (each within the scatter of the next, the first and the last beyond it).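

In this assay, this position, on an aromatic carbon of the shared core, now shows a step beyond the scatter: oxan-4-yl in place of pyridin-4-yl gives a 3.0-fold higher number from compound 2 to compound 3 (0.48 log units; beyond the scatter) on a change that keeps the heavy-atom, donor and acceptor counts and alters only the ring's aromatic character and its hetero atom. Against methoxy, the same oxan-4-yl gives a 1.7-fold higher number from compound 1 to compound 3 (0.22 log units; within the scatter) and so stays within the scatter, which means the only step that can be read as a real difference at this position is the one between the two six-membered rings. No measurement at hand accounts for that difference.

The two features that change together in this step remain unseparated, so the compounds shown cannot tell whether the loss of aromatic character or the exchange of nitrogen for oxygen carries it. Piperidin-4-yl, which pairs a non-aromatic ring with a nitrogen, and cyclohexyl, a non-aromatic ring of carbon only, would each bear on that question at the same aromatic carbon.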